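Adding a Second Chloro to Compound 1

A few compounds are considered here, and "the series" means these few. Any claim that something is new, unique, unknown or untested is made for them only; others in the source may bear on it.

The measured compounds and their numbers:
- compound 1, `O=C(Nc1nc2ccccc2[nH]1)c1cccc(Cl)c1`; in an assay on BV-2 cells for positive allosteric modulation of metabotropic glutamate receptor 5 (Mus musculus), read by Griess assay, with stated times of 1 h and 24 h (on this read-out lower numbers stand for stronger inhibition and higher numbers for weaker inhibition), compound 1 gives 29000 nM
- compound 2, `CN(C(=O)c1cccc(Cl)c1)c1nc2ccccc2[nH]1`; in this assay compound 2 gives 210000 nM
- compound 3, `O=C(Nc1nc2ccccc2[nH]1)c1cccc(C(F)(F)F)c1`; in this assay compound 3 gives 12000 nM

Among these three numbers compound 1 stands second highest. Its nearest neighbour is reached by a 2.4-fold lower number from compound 1 to compound 3 (0.38 log units; beyond the scatter), its furthest by a 7.2-fold higher number from compound 1 to compound 2 (0.86 log units; beyond the scatter); both steps are modest, and both lie beyond the scatter.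

Compound 4, `O=C(Nc1nc2ccccc2[nH]1)c1cc(Cl)ccc1Cl`, differs from compound 1 in one place: chloro in place of hydrogen on an aromatic carbon. Neither measured step is a close match. The step of a 7.2-fold higher number from compound 1 to compound 2 (0.86 log units; beyond the scatter) changes the amide nitrogen, not the aromatic ring, and the step of a 2.4-fold lower number from compound 1 to compound 3 (0.38 log units; beyond the scatter) exchanges one group for another at a carbon that already carries a substituent, whereas compound 4 places a new group on a carbon that is bare in compound 1. Among the compounds with values here, no measured pair shows what such an addition does in this assay. The two known steps being modest, a step of similar or smaller size is expected, and its direction cannot be read from the data; the expectation is therefore placed close to compound 1 with a wide range. For compound 4 in this assay the expected number is 22000 nM, between 7000 nM and 70000 nM. This estimate corresponds to a 1.3-fold lower number from compound 1 to compound 4 (0.12 log units; within the scatter).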

Compound 4, half-maximal inhibitory concentration: 12000 nM
Estimate against measurement, compound 4: 1.8-fold (0.26 log units) above, and the stated range covers the measured number.
By their numbers in this assay, from the lowest: compounds 3 and 4 (each within the scatter of the next); then compound 1; then compound 2.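

Measured in this assay the addition of chloro on an aromatic carbon, ortho to a large group and para to a chloro group, gives a 2.4-fold lower number from compound 1 to compound 4 (0.38 log units; beyond the scatter) and so shows that this ring carbon accepts a new group while the number moves down rather than up. Within the data shown here, the earlier steps concerned only the amide nitrogen and a carbon that already carried a substituent, so this is the first reading of what an addition to a bare ring carbon does, and it settles a direction that could not be read before, for this one group at this one place. Nothing measured on these compounds accounts for the change, which stands here as an observation only.

The compounds shown leave open whether the lower number belongs to chloro itself or would also follow from another group on the same carbon, such as a methyl, a methoxy, an amine or a carboxylic acid. They also leave open what the same chloro would do on the other bare carbons of this ring.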